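This account rests on a few compounds, and the source may have more. Where it says the series, first, only, none or still open, it means among the compounds named here.

Working notes on the series. Compound 1, `O=C1c2ccc(OCc3cccc(-c4ccc(C(F)(F)F)cc4F)c3)cc2CN1C1CCCC1`, was tested in an assay on HEK293 cells for positive allosteric modulation of metabotropic glutamate receptor 2 (Rattus norvegicus), read by thallium flux (a higher number here means that more compound is needed for the effect, a lower number that less compound is needed), and the assay returned only a limit: compound 1 gives > 5000 nM. That is the limit at which compound 1 sits, (the limit of > 5000 nM in this assay, at which 1 of the 3 values shown sits), so no number for it is known, only that it lies at the edge of what this assay reports.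

Two further compounds, built on a different core, were measured. Compound 2, `CN(C)C(=O)c1cc(-c2cccc(COc3ccc4c(=O)n(C5CCCC5)sc4c3)c2)ccc1Cl`, gives 980 nM in this assay. Compound 3, `O=C(O)c1cc(-c2cccc(COc3ccc4c(=O)n(C5CCCC5)sc4c3)c2)ccc1F`, gives 240 nM in this assay. Among the compounds with values here, no single-point step between measured compounds exists, so these two values stand on their own.

Compound 4, `O=C(O)c1ccc(Cl)c(-c2cccc(COc3ccc4c(c3)CN(C3CCCC3)C4=O)c2)c1`, is not yet measured. It keeps the core of compound 1 and changes the pendant aryl group: 5-carboxy-2-chlorophenyl in place of 2-fluoro-4-(trifluoromethyl)phenyl on an aromatic carbon. The entering group is the carboxylic acid pattern also present in compound 3, which sits at 240 nM.

The expected step is an at least 8.3-fold lower number from compound 1 to compound 4 (0.92 log units; beyond the scatter), toward lower numbers and beyond the usual scatter, though with only a limit for the starting point its true size is uncertain. Compound 4 is expected to give about 600 nM in this assay, estimated between 150 nM and 3000 nM.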

Compound 4, half-maximal effective concentration: 90 nM
The estimate for compound 4 lay 6.7-fold (0.82 log units) above the measured number; the measured number lies below the stated range.
By their numbers in this assay, from the lowest: compound 4; then compound 3; then compound 2. At a limit, above all of these: compound 1.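

In this assay compound 1 gives > 5000 nM, which is a limit and not a number. Putting 5-carboxy-2-chlorophenyl in place of 2-fluoro-4-(trifluoromethyl)phenyl on this aromatic carbon, meta to a large group, gives an at least 55-fold lower number from compound 1 to compound 4 (1.74 log units; beyond the scatter), the only step shown at this position, and it shows that a change to the pendant aryl group on the core of compound 1 can move the number well beyond the scatter. The true size of the step stays unknown, since the starting point is only a bound: the limit of > 5000 nM in this assay, at which 1 of the 4 values shown sits.

The compounds shown leave open which part of the entering group carries the step, since the carboxylic acid and the chlorine enter together while the fluorine and the trifluoromethyl leave together. Also open, on these data alone, are how a methyl ester or a tetrazole in place of the carboxylic acid would read in this assay, and whether 5-carboxy-2-chlorophenyl gives a similar result on the core of compound 2 and compound 3.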